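Replacing (Trifluoromethyl)sulfanyl with Tert-Butyl: Solubility Outlook

The source may hold more compounds than are shown below. What is called first, only, known or untested is meant among the compounds shown, and "the series" means these compounds.

Of the compounds shown here, three built on one shared core have been measured in a physicochemical assay for solubility, at pH 7.4; a higher number here means a more soluble compound, a lower number a less soluble compound. Compound 1 `Cc1ccc(NC(=O)Nc2cc(C)nc3ccccc23)cc1` gives 1300 nM. Compound 2 `Cc1cc(NC(=O)Nc2ccc(N)cc2)c2ccccc2n1` carries an amino group where compound 1 carries methyl, and compound 2 gives 18500 nM; a 14-fold higher number from compound 1 to compound 2 (1.15 log units; beyond the scatter). Compound 3 `Cc1cc(NC(=O)Nc2ccc(SC(F)(F)F)cc2)c2ccccc2n1` gives 200 nM, the lowest of the three numbers: a 6.5-fold lower number from compound 1 to compound 3 (0.81 log units; beyond the scatter), and a 93-fold lower number from compound 2 to compound 3 (1.97 log units; beyond the scatter).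

Compound 4 `Cc1cc(NC(=O)Nc2ccc(C(C)(C)C)cc2)c2ccccc2n1` has not yet been measured. It differs from compound 3 in one place: tert-butyl in place of (trifluoromethyl)sulfanyl on an aromatic carbon. Among the compounds with values here, no measured step exchanges these two particular groups, so the expectation rests on the one step that introduced (trifluoromethyl)sulfanyl, from compound 1 to compound 3, which was modest, while the amino group of compound 2 stood far apart from both. Since tert-butyl, like the group it replaces, carries no hydrogen-bond donor, compound 4 is expected to stay near compound 3, and a 1.3-fold higher number from compound 3 to compound 4 (0.10 log units; within the scatter) is expected to fall within the scatter. The estimate for compound 4 in this assay is therefore 250 nM, with a range from 80 nM to 800 nM.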

Compound 4, solubility: 6200 nM
Beside the measured number, compound 4's estimate is 25-fold (1.39 log units) below it; the whole stated range lies below it.
By their numbers in this assay, from the lowest: compound 3; then compound 1; then compound 4; then compound 2.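

In this assay, this change on an aromatic carbon para to a large group gives a 31-fold higher number from compound 3 to compound 4 (1.49 log units; beyond the scatter) even though both groups list 0 hydrogen-bond donors, so sharing that count did not keep the two compounds close. Tert-butyl also gives a 4.8-fold higher number from compound 1 to compound 4 (0.68 log units; beyond the scatter) and yet a 3.0-fold lower number from compound 2 to compound 4 (0.47 log units; beyond the scatter), which places compound 4 between compound 1 and compound 2 and shows that an amino group is not needed to reach a number well above that of compound 1. Within the data shown here, nothing available here explains why swapping these two groups moves the number so far.

Still open, going by these compounds, is whether the high number belongs to tert-butyl alone or would also appear with a close relative such as isopropyl or cyclopropyl. A trifluoromethyl or methoxy group at the same place would show whether compound 3's low number follows the fluorine atoms, the sulfur atom or neither.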